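Bromo on the triazole phenyl: expectation for compound 4

The compounds below may be only part of what the source reports. "The series", "measured", "known", "first", "only" and "open" are said of these compounds alone.

Compound 1 `C=C1C(=O)[C@]23C[C@@]1(O)CC[C@H]2c1ccc(O)c(C)c1[C@@H]3Cn1cc(-c2ccccc2)nn1` gives 750 nM in a functional assay on HL-60 cells (Homo sapiens) for cytotoxicity, read by MTT assay, with a stated time of 4 days; a lower number here means a stronger inhibitor, a higher number a weaker inhibitor. Of the two numbers shown, compound 1 and compound 3 `C=C1C(=O)[C@]23C[C@@]1(O)CC[C@H]2c1ccc(OS(=O)(=O)c2ccc(C)cc2)c(C)c1[C@@H]3Cn1cc(-c2ccc(C)cc2)nn1` sit within the scatter of each other, compound 3 giving 1110 nM in this assay. Compound 2 `C=C1C[C@]23C[C@@]1(O)CC[C@@H]2c1cccc(C)c1[C@@H]3Cn1cc(-c2ccccn2)nn1` reaches only the limit of > 20000 nM in this assay (the limit of > 20000 nM in this assay, at which 1 of the 3 values shown sits). Compound 4 `C=C1C(=O)[C@]23C[C@@]1(O)CC[C@H]2c1ccc(O)c(C)c1[C@@H]3Cn1cc(-c2ccc(Br)cc2)nn1` differs from compound 1 by bromo in place of hydrogen on an aromatic carbon, on an aromatic carbon of a six-membered aromatic ring of carbon only, para to a large group; one bond further out this reads phenyl to 4-bromophenyl. Going by the values given here, no step between measured compounds covers this change. The step expected is a 1.2-fold lower number from compound 1 to compound 4 (0.06 log units; within the scatter), not beyond the scatter in either direction. Compound 4 is estimated at 650 nM, within 250 nM to 2000 nM.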

Compound 4, half-maximal inhibitory concentration: 560 nM
Estimate against measurement, compound 4: 1.2-fold (0.06 log units) above; low and high end bracket the measured number.
By their numbers in this assay, from the lowest: compounds 4, 1 and 3 (each within the scatter of the next). At a limit, above all of these: compound 2.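

In this assay, going by these compounds alone, bromo in place of hydrogen on the six-membered aromatic ring of carbon only, para to a large group, gives a 1.3-fold lower number from compound 1 to compound 4 (0.13 log units; within the scatter) and is the first single-place step. This position therefore accepts bromo with no change beyond the scatter. No measurement shown bears on a cause for this step.

As far as these compounds go, whether an amine or a carboxylic acid at this same position would also stay within the scatter of compound 1 remains open.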